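Furan-3-yl in Place of Isopropyl on an Inactive Core

The compounds below may be only part of what the source reports. "The series", "measured", "known", "first", "only" and "open" are said of these compounds alone.

Of the compounds shown here, three sharing one core have been tested in a functional assay on NPC-TW01 cells (Homo sapiens) for inhibition, read by MTT assay, with a stated time of 72 h (a higher number here means a weaker inhibitor of growth, a lower number a stronger inhibitor of growth), and none of them has produced a number. Compound 1 `COC(=O)c1nc(C)n(-c2ccccc2)n1` is the parent. In this assay compound 1 reaches only the limit of the assay, > 100000 nM. Compound 2 `COC(=O)c1nc(C)n(-c2cccc(Br)c2)n1` puts bromo in place of hydrogen on an aromatic carbon. In this assay compound 2 likewise gives only the limit, > 100000 nM. The step that the two limits leave unreadable from compound 1 to compound 2 therefore carries no readable size.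

Compound 3 `COC(=O)c1nc(C(C)C)n(-c2ccc(F)cc2)n1` carries an isopropyl on the core. In this assay compound 3 also sits at the limit, > 100000 nM. Within the data shown here, compound 3 thus stands exactly where the other two stand, as summarised by the limit of > 100000 nM in this assay, at which 3 of the 3 values shown sit; no measured compound offers a value to compare against.

Compound 4 `COC(=O)c1nc(-c2ccoc2)n(-c2ccc(F)cc2)n1` differs from compound 3 in one place: furan-3-yl in place of isopropyl on an aromatic carbon. Among the measured compounds shown here, no measured step touches this position, and the single measured step, a step that the two limits leave unreadable from compound 1 to compound 2, is itself unreadable. There is accordingly no basis for expecting a readable change in this assay, and the expectation is that compound 4 again reaches only the limit. Compound 4 is expected to give about 120000 nM, within a range from 30000 nM to 500000 nM. The expected step, a step that the limit leaves unreadable from compound 3 to compound 4, is not expected to exceed the scatter.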

Compound 4, concentration for 50% growth inhibition: 11700 nM
Beside the measured number, compound 4's estimate is 10-fold (1.01 log units) above it; the whole stated range lies above it.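

Among these compounds, the aromatic carbon between two ring nitrogen atoms turns out to be a place where a single change moves the result off the limit, which the earlier compounds could not show: in this assay, furan-3-yl in place of isopropyl gives an at least 8.5-fold lower number from compound 3 to compound 4 (0.93 log units; beyond the scatter). Among the compounds shown here, compound 4 is thus the first compound in this set with a real number, and it alone stands apart from the others: the limit of > 100000 nM in this assay, at which 3 of the 4 values shown sit. The change brings in a five-membered aromatic ring and a hydrogen-bond acceptor, neither of which isopropyl has, but because compound 3 gives only a limit, the full size of the step stays unknown, and the single step cannot separate the contributions of the ring, the ring oxygen and the larger group.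

The compounds shown leave open whether the furan oxygen is needed at all, which a phenyl or a thiophene ring at this carbon would address. They also leave open whether an open chain such as n-butyl, or a basic group such as an amine, would serve here, and whether the fluoro on the aryl ring plays any part in the result.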